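The compounds below may be only part of what the source reports. "The series", "measured", "known", "first", "only" and "open" are said of these compounds alone.

Measured compounds:
- compound 1 `COc1ccc(C(=O)NNc2c(Br)cccc2Br)cc1`: > 100000 nM
- compound 2 `CN(C)c1ccc(C(=O)NNc2c(Cl)cccc2Cl)cc1`: > 100000 nM

In a toxicity assay on MDCK cells (Canis lupus familiaris) for cytotoxicity, read by CCK-8 assay, with a stated time of 48 h (a higher number here means that more compound is tolerated, a lower number that less compound is tolerated), compound 1 gives > 100000 nM, which is a limit of the assay and not a number. In the same assay compound 2 gives > 100000 nM, again a limit rather than a measured value. Among the measured compounds shown here, compound 1 therefore stands at the limit of > 100000 nM in this assay, at which 2 of the 2 values shown sit, and no measured step between compounds exists against which a change could be sized.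

Compound 3 `CCN(CC)c1ccc(C(=O)NNc2c(Br)cccc2Br)cc1` has not yet been tested in this assay. It differs from compound 1 by diethylamino in place of methoxy on an aromatic carbon. Since both measured compounds sit at the limit of the assay, nothing here shows that a change on this carbon moves the tolerated concentration, and the step from compound 1 to compound 3 is expected to be none beyond the scatter in this assay. Compound 3 is accordingly expected to give about 100000 nM, with a likely range from 50000 nM to 200000 nM, and the step this estimate means is a number no higher from compound 1 to compound 3 (the limit leaves the size open). The most probable outcome is that compound 3, like compound 1, is reported only as a limit.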

Compound 3, half-maximal cytotoxic concentration: 34000 nM
Beside the measured number, compound 3's estimate is 2.9-fold (0.47 log units) above it; measured number below the stated range.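

In this assay, compound 3 is the first compound shown to give a measured number rather than a limit, so a change on this aromatic carbon, para to a large group, can move the concentration the cells tolerate. Diethylamino in place of methoxy gives an at least 2.9-fold lower number from compound 1 to compound 3 (0.46 log units; beyond the scatter), and this step is beyond the usual scatter, with only its lower bound known since compound 1 is held at a limit. Until this result, the values gave no sign that any change moved the read-out: the limit of > 100000 nM in this assay, at which 2 of the 3 values shown sit.

The compounds shown do not tell which feature of the change lowers the number, and they give no property that would account for it, so it remains open whether a smaller amine such as methylamino, a longer chain such as dipropylamino or a cyclic amine such as pyrrolidine on this carbon would give a number like that of compound 3. Going by these compounds, it also remains open whether the lower number depends on the rest of the core of compound 1 or would appear with a carboxylic acid on this carbon as well.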